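Swapping the Aryl Group on a Triazole in a Cytotoxicity Series

This account rests on a few compounds, and the source may have more. Where it says the series, first, only, none or still open, it means among the compounds named here.

Of the compounds shown here, two from this series have been measured in a functional assay on HeLa cells (Homo sapiens) for cytotoxicity, read by MTT assay, with a stated time of 48 h (on this read-out lower numbers stand for stronger inhibition and higher numbers for weaker inhibition), and a third awaits testing. Compound 1 `COc1cc(OC)c(-n2cc(CO/N=C3\CC[C@]4(C)[C@@H](CC/C=C(\C)CC/C=C(\C)CCC=C(C)C)[C@](C)(O)CC[C@H]4C3(C)C)nn2)c(OC)c1` gives 12800 nM in this assay. Compound 2 `CC(C)=CCC/C(C)=C/CC/C(C)=C/CC[C@@H]1[C@@]2(C)C/C(=C\c3ccc(OCc4cn(-c5ccc(F)cc5)nn4)cc3)C(=O)C(C)(C)[C@@H]2CC[C@@]1(C)O` gives 126000 nM in this assay, the higher of the two numbers, and its gap to compound 1 lies beyond the usual scatter of the method. Compound 3 `CC(C)=CCC/C(C)=C/CC/C(C)=C/CC[C@@H]1[C@@]2(C)C/C(=C\c3ccc(OCc4cn(-c5cccc([N+](=O)[O-])c5)nn4)cc3)C(=O)C(C)(C)[C@@H]2CC[C@@]1(C)O` has not yet been measured. It differs from compound 2 in a single place: 3-nitrophenyl in place of 4-fluorophenyl on an aromatic nitrogen. Among the measured compounds shown here, no pair of measured compounds that differ only in this way is at hand, so the numbers themselves say nothing about what this exchange does. With nothing to build on, the change in this assay is expected to be modest, and a 1.4-fold lower number from compound 2 to compound 3 (0.15 log units; within the scatter) is the step taken as the best guess, with no clear direction beyond the scatter. On that basis compound 3 is estimated to give 90000 nM in this assay, with a plausible range from 30000 nM to 270000 nM.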

Compound 3, half-maximal inhibitory concentration: 32900 nM
The estimate for compound 3 lay 2.7-fold (0.44 log units) above the measured number, within the range that was stated.
By their numbers in this assay, from the lowest: compound 1; then compound 3; then compound 2.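

The aryl group on the aromatic nitrogen of the five-membered aromatic ring with 3 nitrogen proves to matter in this assay: 3-nitrophenyl in place of 4-fluorophenyl gives a 3.8-fold lower number from compound 2 to compound 3 (0.58 log units; beyond the scatter). Among the compounds shown here, the earlier compounds offered no pair differing in one place, so this step is the only direct reading of this position, and it shows that the number responds to the aryl group alone, with the rest of the structure held constant. The exchange changes the substituent and its place on the phenyl ring together, and nothing available accounts for the size or direction of the step.

The compounds shown leave open whether the lower number follows the nitro group or its place on the ring, a question that 4-nitrophenyl and 3-fluorophenyl at this position would separate. They also leave open how an unsubstituted phenyl, a 3-aminophenyl or a phenyl bearing a carboxylic acid would compare, and whether the same exchange would have a similar effect in the oxime-linked structure of compound 1.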